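Changing the Sulfur Side Chain of Compound 3

The compounds below may be only part of what the source reports. "The series", "measured", "known", "first", "only" and "open" are said of these compounds alone.

Three compounds with a shared core have numbers in a functional assay on HT cells (Homo sapiens) for antiproliferative activity, read by fluorescence, with a stated time of 72 h (a lower number here means a stronger inhibitor of growth, a higher number a weaker inhibitor of growth), so far. Compound 2 `CC(C)c1n[nH]c2c(NCc3ccc(-c4ccccn4)cc3)nc(S)nc12` has only a hydrogen on the sulfur and gives 2760 nM in this test. Compound 1 `CC(C)c1n[nH]c2c(NCc3ccc(-c4ccccn4)cc3)nc(SCC(N)CN)nc12` has a 2,3-diaminopropyl group on that sulfur and gives 480 nM as its number. Compound 3 `CC(=O)NCCSc1nc(NCc2ccc(-c3ccccn3)cc2)c2[nH]nc(C(C)C)c2n1` has a 2-acetamidoethyl group there and gives 71 nM as the lowest number of the three, which makes it the strongest growth inhibitor so far.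

Going by the values given here, compound 4 `CCC(O)CSc1nc(NCc2ccc(-c3ccccn3)cc2)c2[nH]nc(C(C)C)c2n1` has 1-hydroxypropyl in place of acetamidomethyl on a saturated chain carbon bound to a sulfur as its only change.

Among the compounds with values here, three measured steps bear on this. The largest is a 39-fold lower number from compound 2 to compound 3 (1.59 log units; beyond the scatter) for adding the 2-acetamidoethyl group. Adding the 2,3-diaminopropyl group gave a modest step, seen in reverse as a 5.8-fold higher number from compound 1 to compound 2 (0.76 log units; beyond the scatter) when that group is removed. The two chains themselves differ by a 6.8-fold lower number from compound 1 to compound 3 (0.83 log units; beyond the scatter) in a step that is also modest. Within the data shown here, none of the measured compounds has a hydroxyl group, so the evidence is indirect. Compound 4 keeps a chain on the sulfur, so a small rise is expected, perhaps none beyond the scatter. The estimate is a 1.7-fold higher number from compound 3 to compound 4 (0.23 log units; within the scatter) as the expected step. For compound 4 the estimated value is 120 nM with an expected range from 40 nM to 360 nM in this test.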

Compound 4, concentration for 50% growth inhibition: 273 nM
Compound 4: the middle estimate sits 2.3-fold (0.36 log units) below what was measured; measured number inside the range.
By their numbers in this assay, from the lowest: compound 3; then compounds 4 and 1 (each within the scatter of the next); then compound 2.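

In this assay, the change on the saturated chain carbon bound to the sulfur costs activity (a 3.8-fold higher number from compound 3 to compound 4 (0.58 log units; beyond the scatter)), which shows that this position does not treat every short side chain alike. Both earlier chains contained nitrogen, whereas 2-hydroxybutyl contains none, yet it still improves on the bare hydrogen (a 10-fold lower number from compound 2 to compound 4 (1.00 log units; beyond the scatter)), so nitrogen in the chain is not needed for a gain over compound 2. The chains of compound 1 and compound 4 carry different groups but cannot be told apart here (a 1.8-fold lower number from compound 1 to compound 4 (0.25 log units; within the scatter), within the scatter), so this assay does not separate the 2,3-diaminopropyl group from the 2-hydroxybutyl group. Nothing in the available data gives a cause for any of these steps.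

Going by these compounds, a plain butyl chain on the sulfur, with no hydroxyl group, would show what the hydroxyl itself contributes to compound 4, and that remains open. Also open, on these data alone, is whether a carboxylic acid at the end of the chain, or a longer chain carrying the acetamide, would give a number closer to that of compound 3 (71 nM).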